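Swapping piperidin-1-yl for diethylamino in compound 3

A few compounds are considered here, and "the series" means these few. Any claim that something is new, unique, unknown or untested is made for them only; others in the source may bear on it.

Values in an ADME assay on HeLa cells (Homo sapiens) for cytotoxicity, read by MTT assay (on this read-out higher numbers stand for weaker inhibition and lower numbers for stronger inhibition), for the measured compounds:
- Compound 1 `COc1ccc(C[C@H]2COC(=O)[C@@H]2Cc2ccc(OCc3cn(-c4ccc(F)cc4)nn3)c(OC)c2)cc1OC` gives >= 600000 nM as a limit of the assay, not a number.
- Compound 2 `COc1ccc(C[C@H]2COC(=O)[C@@H]2Cc2ccc(OCc3cn(Cc4ccc(Cl)cc4)nn3)c(OC)c2)cc1OC` gives 242000 nM as a measured number.
- Compound 3 `COc1ccc(C[C@H]2COC(=O)[C@@H]2Cc2ccc(OCC(=O)N3CCCCC3)c(OC)c2)cc1OC` gives 293000 nM as a measured number.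

Compound 3 lies within the usual scatter of compound 2, so these two cannot be told apart. Compound 4 `CCN(CC)C(=O)COc1ccc(C[C@H]2C(=O)OC[C@@H]2Cc2ccc(OC)c(OC)c2)cc1OC` differs from compound 3 in one place, on a carbonyl carbon, where diethylamino stands in place of piperidin-1-yl diethylamino in place of piperidin-1-yl on a carbonyl carbon and no ring remains in that group.

For the measured compounds named here, no measured step changes this group. The nearest evidence comes from changes elsewhere, and both start from a limit. There is an at least 2.0-fold lower number from compound 1 to compound 3 (0.31 log units; beyond the scatter) on exchanging the triazole-bearing group for (piperidin-1-yl)carbonyl, and there is an at least 2.4-fold lower number from compound 1 to compound 2 (0.39 log units; beyond the scatter) on exchanging 4-fluorophenyl for 4-chlorobenzyl. Compound 2 at 242000 nM and compound 3 at 293000 nM carry quite different groups yet stay within the scatter, so no step beyond the scatter is expected in this assay. The estimated change is a 1.0-fold lower number from compound 3 to compound 4 (0.02 log units; within the scatter) and has no expected direction. For compound 4 the expected value is 280000 nM with an estimated range from 140000 nM to 550000 nM in this assay.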

Compound 4, half-maximal inhibitory concentration: 188000 nM
Estimate against measurement, compound 4: 1.5-fold (0.17 log units) above, and the stated range covers the measured number.
By their numbers in this assay, from the lowest: compounds 4, 2 and 3 (each within the scatter of the next). At a limit, above all of these: compound 1.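

For the compounds shown here, until now no step had touched the group on this carbonyl carbon. Replacing the piperidin-1-yl ring with open-chain diethylamino gives a 1.6-fold lower number from compound 3 to compound 4 (0.19 log units; within the scatter) in this assay, so on this read-out the ring can be opened without a difference that stands out from the scatter. Compound 4 also has a clear step from the triazole-bearing compound, with an at least 3.1-fold lower number from compound 1 to compound 4 (0.50 log units; beyond the scatter), and this size is only a minimum because compound 1 stands at a limit of the assay, not at a number: the limit of >= 600000 nM in this assay, at which 1 of the 4 values shown sits.

What the compounds shown leave open is how far this tolerance extends, since only two amide groups appear at this place. A morpholin-4-yl ring, a dimethylamino group or a carboxylic acid in place of the amide could still move the number beyond the scatter.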